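Chloro on the sulfonamide aryl ring in the aorta series

The compounds below may be only part of what the source reports. "The series", "measured", "known", "first", "only" and "open" are said of these compounds alone.

Measured compounds:
compound 1 `CC(C)c1ccc2c(CNC(=O)CNS(=O)(=O)c3ccccc3)cc(C(=O)O)c-2cc1`, > 100000 nM
compound 2 `CC(C)c1ccc2c(CNC(=O)CNS(=O)(=O)c3ccc(Cl)cc3)cc(C(=O)O)c-2cc1`, > 100000 nM
compound 3 `CC(C)c1ccc2c(CCCCS(=O)(=O)Nc3ccccc3)cc(C(=O)O)c-2cc1`, 8700 nM

In a functional assay on thoracic aorta for antagonist activity at thromboxane A2 receptor (Rattus norvegicus) (on this read-out lower numbers stand for stronger inhibition and higher numbers for weaker inhibition), compound 1 returns only a limit, > 100000 nM. Compound 2 likewise returns only a limit in this assay, > 100000 nM. The change between them is chloro in place of hydrogen on an aromatic carbon, and the step it makes, a step that the two limits leave unreadable from compound 1 to compound 2, cannot be read because of the limit of > 100000 nM in this assay, at which 2 of the 3 values shown sit. Compound 3 is the only one of the three with a number in this assay, 8700 nM; the difference between the core of compound 3 and the core of compound 1 is not broken down here.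

Compound 4 `CC(C)c1ccc2c(CCCCS(=O)(=O)Nc3ccc(Cl)cc3)cc(C(=O)O)c-2cc1` is not yet measured. It differs from compound 3 by chloro in place of hydrogen on an aromatic carbon, the same change as that from compound 1 to compound 2, made on the same kind of position. Within the data shown here, since the only earlier instance of this change gave an unreadable step, there is nothing to argue for a shift in either direction, and compound 4 is expected to stay close to compound 3, with an estimated step of a 1.2-fold lower number from compound 3 to compound 4 (0.09 log units; within the scatter) in this assay. Compound 4 is thus estimated at 7000 nM, within 2500 nM to 25000 nM, in this assay.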

Compound 4, half-maximal inhibitory concentration: 2600 nM
Compound 4: middle estimate off by 2.7-fold (0.43 log units), on the high side; the measured number falls inside the stated range.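

Among these compounds, on the core of compound 3, phenyl to 4-chlorophenyl gives a 3.3-fold lower number from compound 3 to compound 4 (0.52 log units; beyond the scatter) in this assay, which is the only readable instance of this change and a modest one. On the core of compound 1 the same change has no readable size, because compound 1 and compound 2 both return only a limit and no number: the limit of > 100000 nM in this assay, at which 2 of the 4 values shown sit. So the result shows that chloro in place of hydrogen, on an aromatic carbon para to a large group, lowers the number on one core; it does not show that the change carries from one core to another, since the other core offers neither agreement nor disagreement.

From the compounds shown here alone, it remains open whether this step belongs to chloro specifically or would also appear with another group at the same place on the core of compound 3, such as fluoro, methyl or methoxy. Among the compounds shown here, also open is how compound 4 would read with a longer chain carrying the sulfonamide, or with an amine on the same aromatic ring in place of chloro, as a single step from the one pair that can be read here.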